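Swapping bromo for methyl on a hydrazone-linked thiazoline

The compounds below may be only part of what the source reports. "The series", "measured", "known", "first", "only" and "open" are said of these compounds alone.

Measured compounds:
compound 1 `Cc1nnc(SCC(=O)N/N=c2/scc(-c3ccccc3)n2-c2ccccc2)s1` — 65.9%
compound 2 `O=C(CSc1nnnn1-c1ccccc1)N/N=c1/scc(-c2ccc(Br)cc2)n1-c1ccccc1` — 47.9%

In a functional assay on C6 cells (Rattus norvegicus) for cytotoxicity, read by MTT assay, with a stated time of 24 h, tested at 25 ug/mL (on this read-out higher numbers stand for a weaker effect at the one concentration tested and lower numbers for a stronger effect), compound 2 gives 47.9%, the lowest of the two numbers and therefore the stronger effect. Compound 1 gives 65.9% in this assay, a number higher than that of compound 2 by more than the usual scatter, so the two compounds are genuinely separated. Compound 3 `Cc1ccc(-c2cs/c(=N/NC(=O)CSc3nnnn3-c3ccccc3)n2-c2ccccc2)cc1` has not been measured. It differs from compound 2 in one place: methyl in place of bromo on an aromatic carbon. Within the data shown here, nothing among the measured pairs shows what such a swap does in this assay, so only a cautious guess is possible. A small step is expected, a number 7.1 percentage points higher from compound 2 to compound 3 (within the scatter), most likely toward a somewhat higher number, but a change that stays within the scatter would not be surprising. For compound 3 the estimate in this assay is 55%, with a range from 40% to 72%.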

Compound 3, a percentage reported as activity, at one concentration (the size of the read-out at that concentration, not a potency): 38.8%
Beside the measured number, compound 3's estimate is 16.2 percentage points above it; the whole stated range lies above it.
By their numbers in this assay, from the lowest: compounds 3 and 2 (each within the scatter of the next); then compound 1.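

In this assay, among these compounds, the change from 4-bromophenyl to 4-methylphenyl gives a small shift (a number 9.1 percentage points lower from compound 2 to compound 3 (within the scatter)), and this is the first direct reading of such a swap on this core. On these numbers, methyl and bromo cannot be told apart at this aromatic carbon, para to a large group, so the position accepts either group without a clear change in the read-out. Nothing measured here offers an explanation for this result.

As far as these compounds go, it remains open whether an amine, a carboxylic acid or a longer chain at the same position would move the number beyond the scatter. Compound 1 differs from compound 3 in more than one place, so what either group adds over plain hydrogen on this ring also stays unresolved.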